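Removing a core chloro: from compound 3 to compound 4

The compounds below may be only part of what the source reports. "The series", "measured", "known", "first", "only" and "open" are said of these compounds alone.

Measured compounds:
- compound 1, `Nc1nc(Cl)c2ncn(Cc3ccccc3CCl)c2n1`: 69200 nM
- compound 2, `Nc1nc(Cl)c2ncn(Cc3ccc(CCl)cc3)c2n1`: 87100 nM
- compound 3, `ClCc1ccccc1Cn1cnc2nc(Cl)nc(Cl)c21`: 39800 nM

All three were tested in a functional assay on NCI-H322M cells (Homo sapiens) for cytotoxicity, read by sulforhodamine B assay, with a stated time of 48 h; a lower number here means that less compound is tolerated, a higher number that more compound is tolerated. Compound 3 gives the lowest of the three numbers, meaning the cells tolerate it least. Its gap to compound 1 is within the usual scatter of repeat measurements, so these two cannot be told apart on the numbers shown; only its gap to compound 2 lies beyond that scatter.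

The next compound, compound 4 (`ClCc1ccccc1Cn1cnc2ncnc(Cl)c21`), has not yet been tested. It differs from compound 3 in one place: hydrogen in place of chloro on an aromatic carbon. A chloro group leaves the shared core and a hydrogen takes its place; nothing else moves.

Within the data shown here, no measured pair shows what this exact change does, so the expectation rests on the measured compounds alone. Since all three compounds sit in a narrow band, the step is expected to be small, most likely a modest rise in the number with compound 4 tolerated somewhat more, possibly none beyond the scatter. The step from compound 3 to compound 4 is therefore estimated as a 1.5-fold higher number from compound 3 to compound 4 (0.18 log units; within the scatter). Compound 4 is expected to give about 60000 nM, with a plausible range from 20000 nM to 180000 nM.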

Compound 4, concentration lethal to 50% of the cells: 40700 nM
For compound 4 the middle estimate is 1.5-fold (0.17 log units) above the measured one; the measured number falls inside the stated range.
By their numbers in this assay, from the lowest: compounds 3, 4, 1 and 2 (each within the scatter of the next, the first and the last beyond it).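

In this assay, among these compounds, this is the first direct test of the chloro group between two ring nitrogen atoms, and replacing it with hydrogen gives a 1.0-fold higher number from compound 3 to compound 4 (0.01 log units; within the scatter) and so no readable change. With the rest of compound 3 held fixed, the chlorine atom at this position can therefore be removed without any measurable shift in how much compound the cells tolerate. The number in this assay does not depend on that chloro group, at least in this one pair, and nothing measured here explains why.

From the compounds shown here alone, only chloro and hydrogen have been compared at this position, so it remains open whether a larger or different group, such as an amine, a methoxy group or a longer carbon chain, would also leave the number unchanged. Going by these compounds, it is also open whether the remaining chloro group on the shared core could be replaced with as little effect, and whether the same swap would give the same result in other compounds.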